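A few compounds are considered here, and "the series" means these few. Any claim that something is new, unique, unknown or untested is made for them only; others in the source may bear on it.

In a functional assay on PANC-1 cells (Homo sapiens) for antiproliferative activity, read by fluorescence and resazurin assay, with a stated time of 48 h (on this read-out higher numbers stand for weaker inhibition and lower numbers for stronger inhibition), compound 3 (`CCOc1ccc(NC(=O)c2cc3cc([N+](=O)[O-])ccc3oc2=O)cc1`) gives 12100 nM. That value lies within the scatter of the other two: compound 2 (`CCOc1ccc(NC(=O)c2cc3ccc(O)cc3oc2=O)cc1`) gives 14300 nM and compound 1 (`CCOc1ccc(NC(=O)c2cc3cc(Br)ccc3oc2=O)cc1`) gives 16800 nM. Compound 4 (`CCOc1ccc(NC(=O)c2cc3ccccc3oc2=O)cc1`) has hydrogen in place of nitro on an aromatic carbon. Within the data shown here, one measured step bears on this change: a 1.4-fold lower number from compound 1 to compound 3 (0.14 log units; within the scatter), where nitro takes the place of bromo. That step is small, so no step beyond the scatter is expected in this assay, in either direction. Compound 4 is estimated at 15000 nM, with an expected range from 7000 nM to 32000 nM. The expected step is a 1.2-fold higher number from compound 3 to compound 4 (0.09 log units; within the scatter).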

Compound 4, half-maximal inhibitory concentration: 13400 nM
For compound 4 the middle estimate is 1.1-fold (0.05 log units) above the measured one; measured number inside the range.
By their numbers in this assay, from the lowest: compounds 3, 4, 2 and 1 (each within the scatter of the next).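

With hydrogen on this aromatic carbon, compound 4 stays within the scatter of all three substituted compounds in this assay: a 1.1-fold higher number from compound 3 to compound 4 (0.04 log units; within the scatter), a 1.1-fold lower number from compound 2 to compound 4 (0.03 log units; within the scatter) and a 1.3-fold lower number from compound 1 to compound 4 (0.10 log units; within the scatter). Having no group at all here therefore separates neither from nitro or bromo at this carbon nor from the hydroxy of compound 2. No measurement at hand offers an explanation for this flat result.

On these data alone, whether an amine or a carboxylic acid on this carbon would give a step beyond the scatter remains open. So does whether this position affects the read-out at all.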